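This account rests on a few compounds, and the source may have more. Where it says the series, first, only, none or still open, it means among the compounds named here.

Measured so far in a functional assay on MDA-MB-231 cells (Homo sapiens) for cytotoxicity, read by MTT assay, with a stated time of 72 h; a lower number here means a stronger inhibitor, a higher number a weaker inhibitor:

Compound 1, `N=C(Nc1ccccc1)c1cc2cn[nH]c2cn1`, gives > 50000 nM, which is a limit of the assay and not a number.
Compound 2, `COc1ccc(Cn2ncc3cc(C(=N)Nc4ccc(N5CCN(C)CC5)cc4)ncc32)cc1`, gives 5700 nM.
Compound 3, `COc1ccc(Cn2ncc3cc(C(=N)Nc4ccccc4)ncc32)cc1`, gives 34700 nM.

Of the two numbers, compound 3 has the highest; its nearest neighbour is compound 2, and the step between them is a 6.1-fold higher number from compound 2 to compound 3 (0.78 log units; beyond the scatter). Compound 1 sits at the limit of > 50000 nM in this assay, at which 1 of the 3 values shown sits, so the step of an at least 1.4-fold lower number from compound 1 to compound 3 (0.15 log units; that floor lies within the scatter) only has a floor, which lies within the scatter.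

Compound 4, `COc1ccc(Cn2ncc3cc(C(=N)Nc4cccc(C(F)(F)F)c4)ncc32)cc1`, differs from compound 3 by trifluoromethyl in place of hydrogen on an aromatic carbon. For the measured compounds named here, none of the measured steps tries this group. Going by the values given here, the only change on the same phenyl, a 6.1-fold higher number from compound 2 to compound 3 (0.78 log units; beyond the scatter), removed a much larger group of a different kind, and it says little about a small group placed as in compound 4. Among the compounds with values here, with no closer precedent, the most defensible expectation is a step that stays within the scatter, or at most a modest lowering.

Compound 4 is therefore estimated at 20000 nM, in this assay, with a likely range from 6000 nM to 60000 nM. That estimate corresponds to an expected step of a 1.7-fold lower number from compound 3 to compound 4 (0.24 log units; within the scatter).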

Compound 4, half-maximal inhibitory concentration: 29800 nM
Estimate against measurement, compound 4: 1.5-fold (0.17 log units) below; the measured number falls inside the stated range.
By their numbers in this assay, from the lowest: compound 2; then compounds 4 and 3 (each within the scatter of the next). At a limit, above all of these: compound 1.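

In this assay, trifluoromethyl is the first small group shown on the phenyl of compound 3, and it sits meta to a large group; the result is a 1.2-fold lower number from compound 3 to compound 4 (0.07 log units; within the scatter), so the two compounds cannot be told apart in this assay. Adding these four heavy atoms at this place on the phenyl therefore buys no measurable gain, and the only step on this ring that lies beyond the scatter is still the one involving the much larger 4-methylpiperazin-1-yl group, a 6.1-fold higher number from compound 2 to compound 3 (0.78 log units; beyond the scatter). Nothing measured here offers a reason why the trifluoromethyl step stays so small.

A single group at this place cannot show whether the position is insensitive to substitution in general, so an amine such as dimethylamino or a carboxylic acid on the same carbon could still give a number clearly apart from that of compound 3. From the compounds shown here alone, it also remains open whether trifluoromethyl would give the same result on another carbon of the phenyl, or whether a longer chain ending in an amine would do better here.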